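This account rests on a few compounds, and the source may have more. Where it says the series, first, only, none or still open, it means among the compounds named here.

Measured so far: compound 1 `CCOc1ccc(-c2c(C#N)c(N)nc(SCc3ccn[nH]3)c2C#N)cc1` gives 332 nM in a functional assay on CHO cells for agonist activity at adenosine receptor A2b (Homo sapiens), read by AlphaScreen and cAMP accumulation; a higher number here means that more compound is needed for the effect, a lower number that less compound is needed; compound 2 `N#Cc1c(N)nc(SCc2ncn[nH]2)c(C#N)c1-c1ccc(OCC2CC2)cc1` gives 51 nM; compound 3 `N#Cc1c(N)nc(SCc2ccn[nH]2)c(C#N)c1-c1ccc(OCC2CC2)cc1` gives 84 nM. Compound 1 stands highest of the three numbers; its nearest neighbour is compound 3, a 4.0-fold lower number from compound 1 to compound 3 (0.60 log units; beyond the scatter). The unmeasured compound 4 `CCOc1ccc(-c2c(C#N)c(N)nc(SCC(=O)NC)c2C#N)cc1` differs from compound 1 at the sulfur-bound chain carbon: methylcarbamoyl in place of 1H-pyrazol-5-yl on a saturated chain carbon bound to a sulfur. Within the data shown here, only one measured step touches that position, and it swaps one five-membered aromatic ring for another, a 1.6-fold higher number from compound 2 to compound 3 (0.22 log units; within the scatter). Among the measured compounds shown here, no step exchanges the ring for a chain group, so the data give no firm direction. Compound 4 is therefore expected to stay close to compound 1, with a small step estimated as a 1.4-fold higher number from compound 1 to compound 4 (0.13 log units; within the scatter), and an estimated value of 450 nM, within 120 nM to 1700 nM.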

Compound 4, half-maximal effective concentration: 211 nM
For compound 4 the middle estimate is 2.1-fold (0.33 log units) above the measured one; measured number inside the range.
By their numbers in this assay, from the lowest: compounds 2 and 3 (each within the scatter of the next); then compounds 4 and 1 (each within the scatter of the next).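

In this assay, the exchange of a ring for an open chain group on the saturated chain carbon bound to a sulfur gives a 1.6-fold lower number from compound 1 to compound 4 (0.20 log units; within the scatter) and so leaves the number within the scatter. Earlier compounds had shown only one five-membered aromatic ring exchanged for another, whereas here methylcarbamoyl, with no ring, reads alike with 1H-pyrazol-5-yl. No measurement given explains this. As far as these compounds go, whether methylcarbamoyl behaves the same way alongside the cyclopropyl group of compound 3 remains open. So does the outcome with a carboxylic acid, an amine or a longer chain at this position.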